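Adding a Vinyl Group to an Aryl Methyl Substituent

The compounds below may be only part of what the source reports. "The series", "measured", "known", "first", "only" and "open" are said of these compounds alone.

Measured compounds in an assay on isolated protein for inhibition of leukotriene B4 receptor 1 (Homo sapiens), tested at 10 uM; a lower number here means less inhibition, a higher number more inhibition at the concentration tested (going by the name of the read-out):
compound 1 `CC(=O)c1cc(C)c(OCCCCC#N)cc1O` gives 79%
compound 2 `CC(=O)c1cc(CC(C)O)c(OCCCCC#N)cc1O` gives 10%
compound 3 `C=CCc1cc(C(C)=O)c(O)cc1OCC#N` gives 20%

Compound 1 stands highest of the three numbers, with compound 3 nearest and compound 2 furthest below it. The unmeasured compound 4 `C=CCc1cc(C(C)=O)c(O)cc1OCCCCC#N` differs from compound 1 by vinyl in place of hydrogen on a saturated chain carbon bound to an aromatic carbon. Among the measured compounds shown here, one measured step bears on this position: a number 69 percentage points lower from compound 1 to compound 2 (beyond the scatter). For the measured compounds named here, compound 3, which carries allyl at this position on a shorter chain, also sits well below compound 1, though no single step links it to compound 4. A downward step is therefore expected for compound 4, a number 44 percentage points lower from compound 1 to compound 4 (beyond the scatter). Compound 4 is estimated at 35%, in the range 10% to 65%.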

Compound 4, a percentage reported as inhibition, at one concentration (the size of the read-out at that concentration, not a potency): 92%
Beside the measured number, compound 4's estimate is 57 percentage points below it, outside the stated range (above it).
By their numbers in this assay, from the lowest: compounds 2 and 3 (each within the scatter of the next); then compound 1; then compound 4.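

In this assay, vinyl in place of hydrogen on a saturated chain carbon bound to an aromatic carbon gives a number 13 percentage points higher from compound 1 to compound 4 (beyond the scatter) so growth at this place does not by itself lower the number. The group that enters decides the outcome, as vinyl in place of 1-hydroxyethyl gives a number 82 percentage points higher from compound 2 to compound 4 (beyond the scatter) and the other end of the molecule counts too, with 3-cyanopropyl in place of cyano giving a number 72 percentage points higher from compound 3 to compound 4 (beyond the scatter) in the same series. No measurement here explains these differences. As far as these compounds go, whether an amine, a carboxylic acid or a longer chain in place of vinyl would keep this high number remains open.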